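Piperidinylethyl Amine in Place of a Bromobenzyl Amine

The compounds below may be only part of what the source reports. "The series", "measured", "known", "first", "only" and "open" are said of these compounds alone.

Of the compounds shown here, three on one shared core have been measured in an assay on HEK293 cells for inhibition of Steryl-sulfatase (Homo sapiens), tested at 0.1 uM; a lower number here means a weaker effect, a higher number a stronger effect of the compound at the concentration tested. Compound 1 `CCN(Cc1cccnc1)c1ccc(C(=O)N2CCc3ccc(OS(N)(=O)=O)cc3C2)cc1` gives 35.7%, compound 2 `CC(C)CCN(CCC(C)C)c1cccc(C(=O)N2CCc3ccc(OS(N)(=O)=O)cc3C2)c1` gives 32.3%, and compound 3 `CCN(Cc1cccc(Br)c1)c1cccc(C(=O)N2CCc3ccc(OS(N)(=O)=O)cc3C2)c1` gives 20.9%, the lowest of the three numbers, with compound 2 nearest to it and compound 1 furthest. Within the data shown here, the one single-point step among them is a number 11.4 percentage points lower from compound 2 to compound 3 (beyond the scatter). Compound 4 `CN(CCN1CCCCC1)c1cccc(C(=O)N2CCc3ccc(OS(N)(=O)=O)cc3C2)c1` differs from compound 3 by methyl(2-(piperidin-1-yl)ethyl)amino in place of (3-bromobenzyl)(ethyl)amino on an aromatic carbon. The amine that enters resembles the diisopentylamino of compound 2 more than the group it replaces, so a step back upward is expected, because compound 2 gives 32.3% in this assay. For compound 4 in this assay an inhibition of 30% is estimated, with a range from 15% to 45%. This estimate is expected to mean a step of a number 9.1 percentage points higher from compound 3 to compound 4 (within the scatter).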

Compound 4, a percentage reported as inhibition, at one concentration (the size of the read-out at that concentration, not a potency): 24.5%
For compound 4 the middle estimate is 5.5 percentage points above the measured one, and the stated range covers the measured number.
By their numbers in this assay, from the lowest: compounds 3, 4, 2 and 1 (each within the scatter of the next, the first and the last beyond it).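

In this assay the change gives a number 3.6 percentage points higher from compound 3 to compound 4 (within the scatter) and the comparison with the diisopentylamino amine gives a number 7.8 percentage points lower from compound 2 to compound 4 (within the scatter) even though the two amines on either side are separated by a number 11.4 percentage points lower from compound 2 to compound 3 (beyond the scatter) in this read-out. The methyl(2-(piperidin-1-yl)ethyl)amino group, with its non-aromatic ring and second nitrogen, therefore cannot be told apart from either of them at this position. No evidence bears on why the numbers fall this way. Still open, from the compounds shown here alone, is whether a morpholine in place of the piperidine, or a longer chain between the two nitrogens, would separate from these amines.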